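Reversing an amide on the lactam ring: compound 4

The compounds below may be only part of what the source reports. "The series", "measured", "known", "first", "only" and "open" are said of these compounds alone.

Measured so far:
Compound 1, `Cc1nn(-c2ncnc3nc[nH]c23)c2c1C(OCc1ccccc1Cl)CC(=O)N2`, gives 2 nM in a functional assay on HEK293 cells for agonist activity at G-protein coupled receptor 39 (Homo sapiens), read by scintillation proximity assay and inositol phosphate accumulation, with a stated time of 75 min, in the presence of a further agent that is not named here; a lower number here means that less compound is needed, a higher number that more compound is needed for the effect.
Compound 2, `Cc1nn(-c2ncnc3nc[nH]c23)c2c1C(C(=O)NCc1ccccc1)CC(=O)N2`, gives 5 nM.
Compound 3, `Cc1nn(-c2ncnc3nc[nH]c23)c2c1C(C(=O)Nc1ccccc1)CC(=O)N2`, gives 10 nM.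

Compound 3 has the highest number of the three. Its nearest neighbour is compound 2, and the step of a 2.0-fold higher number from compound 2 to compound 3 (0.30 log units; within the scatter) lies within the scatter, so the two cannot be ordered. Against compound 1 the step of a 5.0-fold higher number from compound 1 to compound 3 (0.70 log units; beyond the scatter) is beyond the scatter, as is a 2.5-fold higher number from compound 1 to compound 2 (0.40 log units; beyond the scatter).

Compound 4, `Cc1nn(-c2ncnc3nc[nH]c23)c2c1C(NC(=O)c1ccccc1)CC(=O)N2`, differs from compound 3 by benzamido in place of phenylcarbamoyl on a saturated ring carbon. Going by the values given here, no measured step exchanges these two groups: the three known steps either replace the (2-chlorobenzyl)oxy group or swap phenyl for benzyl on the amide-type nitrogen, and all were modest or within the scatter. The shared core is kept and the same atoms are merely joined differently, so only a small step is expected in this assay, in either direction.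

Compound 4 is therefore estimated at 15 nM, with a range of 4 nM to 60 nM, which is expected to mean a step of a 1.5-fold higher number from compound 3 to compound 4 (0.18 log units; within the scatter).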

Compound 4, half-maximal effective concentration: 3 nM
Estimate against measurement, compound 4: 5.0-fold (0.70 log units) above, and the stated range ends above it.
By their numbers in this assay, from the lowest: compounds 1, 4, 2 and 3 (each within the scatter of the next, the first and the last beyond it).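

In this assay, going by these compounds alone, the same atoms joined the other way round on the saturated ring carbon do not give the same number: benzamido in place of phenylcarbamoyl is a step beyond the scatter (a 3.3-fold lower number from compound 3 to compound 4 (0.52 log units; beyond the scatter)), so the direction of the amide can be read at this position, which no earlier step showed. The two other steps lie within the scatter (a 1.7-fold lower number from compound 2 to compound 4 (0.22 log units; within the scatter); a 1.5-fold higher number from compound 1 to compound 4 (0.18 log units; within the scatter)), so benzamido cannot be ordered against benzylcarbamoyl or (2-chlorobenzyl)oxy. Nothing given here bears on why the direction of the amide changes the number.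

The compounds shown leave open how a plain amine or a longer phenylacetamido chain on the same saturated ring carbon would compare. They also leave open whether a chlorine on the benzamido ring would move the number beyond the scatter.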